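Swapping Isopropylsulfanyl for Propoxy on the Shared Core

The source may report more compounds than this note shows. Statements on the series, on what has been measured and on what is new or still open speak of the compounds shown alone.

Of the compounds shown here, two sharing one core have been tested in an ADME assay on HFF cells (Homo sapiens) for cytotoxicity, with a stated time of 8 days; a lower number here means that less compound is tolerated, a higher number that more compound is tolerated. Compound 1 `CCCCCOc1nc(N)nc2c1ncn2/C=C1/CC1(CO)CO` gives 259000 nM. Compound 2 `CC(C)Sc1nc(N)nc2c1ncn2/C=C1/CC1(CO)CO` gives > 300000 nM, which is a limit of the assay and not a number. Compound 3 `CCCOc1nc(N)nc2c1ncn2/C=C1/CC1(CO)CO` has not yet been measured. It differs from compound 2 in one place, with propoxy in place of isopropylsulfanyl on an aromatic carbon. Going by the values given here, one measured step bears on this change, because it touches the same aromatic carbon: an at least 1.1-fold higher number from compound 1 to compound 2 (0.06 log units; that floor lies within the scatter). That step swaps pentyloxy for isopropylsulfanyl, and its floor lies within the scatter. The new propoxy group is another chain joined through oxygen, like the pentyloxy of compound 1, which gives 259000 nM. No change beyond the scatter is therefore expected in this assay. The expected step is an at least 1.0-fold lower number from compound 2 to compound 3 (0.01 log units; that floor lies within the scatter). For compound 3 the estimate is 290000 nM, within a range of 160000 nM to 500000 nM.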

Compound 3, half-maximal cytotoxic concentration: > 300000 nM
Compound 3: only a limit was reported; the forecaster's own chance of this, stated with the estimate: 60%; at least 1.0-fold (0.01 log units) between middle value and limit.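

In this assay compound 3 gives > 300000 nM, which is a limit of the assay and not a number. Shortening the oxygen-linked chain on this aromatic carbon from pentyloxy to propoxy gives an at least 1.1-fold higher number from compound 1 to compound 3 (0.06 log units; that floor lies within the scatter), so this change shows no difference beyond the scatter, although the true size of the step could be larger than this floor. The step between the isopropylsulfanyl and propoxy compounds cannot be read, and the ceiling of the assay hides any difference between them: the limit of > 300000 nM in this assay, at which 2 of the 3 values shown sit.

From the compounds shown here alone, how far compound 2 and compound 3 really lie past that limit stays open. Also open, going by these compounds, is whether an amine, a carboxylic acid or a chain longer than pentyloxy on this aromatic carbon would give a clearly lower number.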